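Adding a methoxy group: effect on cell cytotoxicity

A few compounds are considered here, and "the series" means these few. Any claim that something is new, unique, unknown or untested is made for them only; others in the source may bear on it.

Measured so far in an ADME assay on HEK293 cells (Homo sapiens) for cytotoxicity, read by MTT assay; on this read-out higher numbers stand for weaker inhibition and lower numbers for stronger inhibition: compound 1 `COc1ccc(-n2ncn(Cc3cn(Cc4cc5cc(Cl)ccc5nc4Cl)nn3)c2=O)cc1` gives 1060 ug/mL; compound 2 `O=c1n(Cc2cn(Cc3cc4ccc(Cl)cc4nc3Cl)nn2)cnn1-c1ccccc1` gives 869 ug/mL; compound 3 `O=c1n(Cc2cn(Cc3cc4cc(Cl)ccc4nc3Cl)nn2)cnn1-c1ccccc1` gives 459 ug/mL.

Compound 1 and compound 3 share one core and differ only by methoxy in place of hydrogen on an aromatic carbon. That change gave a 2.3-fold higher number from compound 3 to compound 1 (0.36 log units; beyond the scatter). Compound 2 is built from the same atoms as compound 3, joined differently; the difference between the two cores is not broken down here. Compound 4 `COc1ccc(-n2ncn(Cc3cn(Cc4cc5ccc(Cl)cc5nc4Cl)nn3)c2=O)cc1` is not yet measured. It differs from compound 2 by methoxy in place of hydrogen on an aromatic carbon, the same change as from compound 3 to compound 1, at the same place. For the measured compounds named here, because the single measured instance of this change gave a 2.3-fold higher number from compound 3 to compound 1 (0.36 log units; beyond the scatter), a step of similar size is expected for compound 4: a 2.0-fold higher number from compound 2 to compound 4 (0.29 log units; within the scatter). Compound 4 is estimated to give 1700 ug/mL in this assay, likely between 850 ug/mL and 3400 ug/mL, a wide range since one example is a thin base.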

Compound 4, half-maximal inhibitory concentration: 1470 ug/mL
Estimate against measurement, compound 4: 1.2-fold (0.06 log units) above; measured number inside the range.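

In this assay, going from phenyl to 4-methoxyphenyl on the second core gave a 1.7-fold higher number from compound 2 to compound 4 (0.23 log units; within the scatter). Set beside the earlier case, the two steps do not differ, so the change carried over from one core to the other: the same change on two cores in this assay, a 2.3-fold higher number (0.36 log units; beyond the scatter) from compound 3 to compound 1 and a 1.7-fold higher number (0.23 log units; within the scatter) from compound 2 to compound 4, 1.4-fold (0.14 log units) apart, within the scatter of two such steps. For the compounds shown here, this rests on only two pairs, and the new step on its own lies within the scatter, so it shows agreement between these two cores, not a firm effect on other cores, and it gives no reason for the step.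

The compounds shown carry only hydrogen or methoxy at this place on the phenyl ring. As far as these compounds go, how an ethoxy group, a longer chain, an amine or a carboxylic acid there would read stays open.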